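The compounds below may be only part of what the source reports. "The series", "measured", "known", "first", "only" and "open" are said of these compounds alone.

In an assay on THP-1 cells for displacement of a labelled ligand from C-C chemokine receptor type 1 (Homo sapiens) (on this read-out lower numbers stand for stronger inhibition and higher numbers for weaker inhibition), compound 1 `Cc1ccc(C(=O)N[C@@H](C(=O)N2CCC(c3ccc(Cl)cc3)CC2)C(C)C)cc1` gives 25 nM, compound 2 `CC(C)CCC(=O)N[C@@H](C(=O)N1CCC(c2ccc(Cl)cc2)CC1)C(C)C` gives 26 nM, and compound 3 `CC(C)[C@@H](NC(=O)CC1CC1)C(=O)N1CCC(c2ccc(Cl)cc2)CC1` gives 46 nM. Compound 3 holds the highest of the three numbers, yet both a 1.8-fold higher number from compound 1 to compound 3 (0.26 log units; within the scatter) and a 1.8-fold higher number from compound 2 to compound 3 (0.25 log units; within the scatter) lie within the scatter, as does a 1.0-fold higher number from compound 1 to compound 2 (0.02 log units; within the scatter). Compound 4 `CC(C)[C@@H](NC(=O)c1ccc(F)cc1)C(=O)N1CCC(c2ccc(Cl)cc2)CC1` carries 4-fluorophenyl in place of cyclopropylmethyl on a carbonyl carbon. The most relevant earlier step is a 1.8-fold higher number from compound 1 to compound 3 (0.26 log units; within the scatter), which exchanged a six-membered aromatic ring on the carbonyl carbon for cyclopropylmethyl; compound 4 brings a six-membered aromatic ring back. Because a 1.8-fold higher number from compound 1 to compound 3 (0.26 log units; within the scatter) stayed within the scatter, compound 4 is expected to show a 1.6-fold lower number from compound 3 to compound 4 (0.22 log units; within the scatter), nothing beyond the scatter. The estimate for compound 4 in this assay is 28 nM, between 12 nM and 65 nM.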

Compound 4, half-maximal inhibitory concentration: 118 nM
Compound 4: middle estimate off by 4.2-fold (0.62 log units), on the low side; the measured number lies above the stated range.
By their numbers in this assay, from the lowest: compounds 1, 2 and 3 (each within the scatter of the next); then compound 4.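

In this assay this carbonyl carbon proves sensitive to what the aromatic ring carries: a 4.7-fold higher number from compound 1 to compound 4 (0.67 log units; beyond the scatter) is a step beyond the scatter, with fluoro in place of methyl on an aromatic carbon. A six-membered aromatic ring alone does not keep the number low, as 4-fluorophenyl also gives a 2.6-fold higher number from compound 3 to compound 4 (0.41 log units; beyond the scatter) and a 4.5-fold higher number from compound 2 to compound 4 (0.66 log units; beyond the scatter) against the saturated groups. No measurement shown here accounts for these steps. Still open, on these data alone, is how an unsubstituted phenyl, or a phenyl bearing a methoxy group, an amine or a carboxylic acid, would read at this place.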